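This account rests on a few compounds, and the source may have more. Where it says the series, first, only, none or still open, it means among the compounds named here.

Working notes on the series in a functional assay on MDA-MB-231 cells (Homo sapiens) for cytotoxicity, read by MTT assay; on this read-out lower numbers stand for stronger inhibition and higher numbers for weaker inhibition.

So far the series gives no readable number. Compound 1 `c1ccc(-c2nnc(-c3c[nH]c4ccccc34)o2)cc1` sits at the limit of the assay, returning > 1000000 nM. Compound 2 `c1ccc2c(-c3nnc(-c4ccncc4)o3)c[nH]c2c1` likewise returns only the limit, > 1000000 nM. Compound 3 `Clc1ccc(-c2nnc(-c3c[nH]c4ccccc34)o2)cc1`, which carries the 4-chlorophenyl group, also stands at the limit, with > 1000000 nM. The steps between these three are therefore unreadable: a step that the two limits leave unreadable from compound 1 to compound 2, a step that the two limits leave unreadable from compound 1 to compound 3 and a step that the two limits leave unreadable from compound 2 to compound 3, since every member of every pair rests at the same limit (the limit of > 1000000 nM in this assay, at which 3 of the 3 values shown sit). Compound 3 thus stands exactly where compound 1 and compound 2 stand, at the limit, and nothing on the numbers shown separates it from them.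

The next change, from compound 3 to compound 4 `FC(F)(F)c1nnc(-c2c[nH]c3ccccc23)o1`, is trifluoromethyl in place of 4-chlorophenyl on an aromatic carbon. Going by the values given here, none of the measured steps gives a size or a direction for a change of this kind; all three pairs sit at the limit (the limit of > 1000000 nM in this assay, at which 3 of the 3 values shown sit), so no magnitude beyond the scatter can be read from them. The expectation for compound 4 in this assay is accordingly that it remains at the limit, with a step that the limit leaves unreadable from compound 3 to compound 4 expected to stay unreadable. Compound 4 is estimated at 1500000 nM, within a range from 300000 nM to 10000000 nM.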

Compound 4, half-maximal inhibitory concentration: > 1000000 nM
Compound 4: no number, only a limit; the forecaster's own chance of this, stated with the estimate: 85%; the middle value is on the limit's open side.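

In this assay compound 4 returns only a limit, > 1000000 nM. No step linking compound 4 with compound 1, compound 2 or compound 3 can be read, because all of them rest at the same limit: the limit of > 1000000 nM in this assay, at which 4 of the 4 values shown sit.

The compounds shown leave open whether any group at this place on the shared core gives a readable value in this assay.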